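A few compounds are considered here, and "the series" means these few. Any claim that something is new, unique, unknown or untested is made for them only; others in the source may bear on it.

Compound 3 `CC(C)c1onc(-c2c(Cl)cccc2Cl)c1COc1ccc(-c2nc3ccc(C(=O)O)cc3n2CC2CCCCC2)c(Cl)c1` gives 160 nM in an assay on HEK-293T cells for antagonist activity at vitamin D3 receptor (Homo sapiens), read by a luciferase reporter, with a stated time of 24 h (a lower number here means a stronger inhibitor, a higher number a weaker inhibitor), the lowest of the three numbers: compound 2 `CC(C)c1onc(-c2c(Cl)cccc2Cl)c1COc1ccc(-c2nc3ccc(C(=O)O)cc3n2C)c(Cl)c1` gives 3520 nM and compound 1 `CCC(CC)n1c(-c2ccc(OCc3c(-c4c(Cl)cccc4Cl)noc3C(C)C)cc2)nc2ccc(C(=O)O)cc21` gives 5690 nM. Among the compounds with values here, the one measured step that bears on the new compound is a 22-fold lower number from compound 2 to compound 3 (1.34 log units; beyond the scatter). Compound 4 `CCC(CC)n1c(-c2ccc(OCc3c(-c4c(Cl)cccc4Cl)noc3C(C)C)cc2Cl)nc2ccc(C(=O)O)cc21` carries the change (pentan-3-yl in place of cyclohexylmethyl on an aromatic nitrogen). The smaller branched chain sits between the hydrogen of compound 2 and the ring-bearing group of compound 3. Compound 1 differs from compound 4 elsewhere but also carries pentan-3-yl, and in this assay compound 1 gives only 5690 nM. For compound 4 a weakening step is therefore expected, estimated as a 4.4-fold higher number from compound 3 to compound 4 (0.64 log units; beyond the scatter). Compound 4 is thus expected to give about 700 nM, within a range from 200 nM to 2500 nM.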

Compound 4, half-maximal inhibitory concentration: 1010 nM
For compound 4 the middle estimate is 1.4-fold (0.16 log units) below the measured one; low and high end bracket the measured number.
By their numbers in this assay, from the lowest: compound 3; then compound 4; then compounds 2 and 1 (each within the scatter of the next).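

In this assay the group on the aromatic nitrogen sets a graded order: pentan-3-yl in place of cyclohexylmethyl loses activity (a 6.3-fold higher number from compound 3 to compound 4 (0.80 log units; beyond the scatter)), yet pentan-3-yl in place of methyl gains it (a 3.5-fold lower number from compound 2 to compound 4 (0.54 log units; beyond the scatter)). With pentan-3-yl held fixed, chloro in place of hydrogen on an aromatic carbon also matters (a 5.6-fold lower number from compound 1 to compound 4 (0.75 log units; beyond the scatter)), so this chain is not the only part of the molecule that moves the number. Nothing measured here explains either effect. Going by these compounds, how a longer straight chain, or a chain ending in an amine, would behave on this nitrogen stays open.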